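Amino for nitro on the aryl ether tail of a uracil

A few compounds are considered here, and "the series" means these few. Any claim that something is new, unique, unknown or untested is made for them only; others in the source may bear on it.

Measured compounds:
Compound 1, `O=c1ccn(CCCCCOc2ccc([N+](=O)[O-])cc2)c(=O)[nH]1`, in an ADME assay on HEL cells (Homo sapiens) for cytotoxicity (on this read-out lower numbers stand for higher toxicity in this test and higher numbers for lower toxicity in this test), compound 1 shows "not determined" (no result reported).
Compound 2, `CCCOC(=O)c1ccc(OCCCCCn2ccc(=O)[nH]c2=O)cc1`, in this assay compound 2 reaches only a limit of the test, > 100000 nM.

Compound 1 has no single number in this assay; of the two results shown, one sits at the limit of > 100000 nM in this assay, at which 1 of the 2 values shown sits. Compound 3, `Nc1ccc(OCCCCCn2ccc(=O)[nH]c2=O)cc1`, shares the core of compound 1 and differs from it in one place: amino in place of nitro on an aromatic carbon. With no number for compound 1, the step to compound 3 in this assay cannot be measured against it, and nothing beyond the scatter is expected in either direction. Resting on the limit seen for compound 2, compound 3 is expected at 100000 nM in this assay, within a range from 30000 nM to 300000 nM, most likely reported again only as a limit.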

Compound 3, half-maximal cytotoxic concentration: > 100000 nM
Compound 3: only a limit was reported (the forecaster's own chance of this, stated with the estimate: 70%); the middle value sits exactly at the limit.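

Compound 1 has no single number, and no step to compound 3 can be read from it or from compound 2, because compound 2 and compound 3 both rest on one limit: the limit of > 100000 nM in this assay, at which 2 of the 3 values shown sit.

The compounds shown leave open where the true values of compound 2 and compound 3 lie in this assay, and whether amino in place of nitro shifts the read-out at all.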